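Efficacy of a Thiazole Acetic Acid Series Against Ring Changes

A few compounds are considered here, and "the series" means these few. Any claim that something is new, unique, unknown or untested is made for them only; others in the source may bear on it.

Measured compounds:
Compound 1 `O=C(O)Cc1sc(C(c2ccc(F)cc2)c2ccc(F)cc2)nc1-c1cc(F)cc(F)c1` gives 80% in an in vitro functional assay on HEK285-7 cells for antagonist activity at prostaglandin D2 receptor 2 (Homo sapiens), read by BRET and beta-arrestin recruitment; on this read-out higher numbers stand for larger maximal responses and lower numbers for smaller maximal responses.
Compound 2 `O=C(O)Cc1sc(C(c2ccc(F)cc2)c2ccc(F)cc2)nc1-c1ccncc1` gives 80% in this assay.
Compound 3 `O=C(O)Cc1sc(C(c2ccc(F)cc2)c2ccc(F)cc2)nc1-c1cc(F)nc(F)c1` gives 80% in this assay.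

Compound 3 stands level with compounds 1 and 2 at the digits shown; the steps of no change at the digits printed from compound 1 to compound 3 (within the scatter) and no change at the digits printed from compound 2 to compound 3 (within the scatter) both lie within the scatter, as does no change at the digits printed from compound 1 to compound 2 (within the scatter). Across these three compounds, exchanging the aryl group on the shared core has left the maximal response unchanged.

Compound 4 `CN(C)c1cc(-c2nc(C(c3ccc(F)cc3)c3ccc(F)cc3)sc2CC(=O)O)ccn1` is not yet measured. Its change from compound 3 is 2-(dimethylamino)pyridin-4-yl in place of 2,6-difluoropyridin-4-yl on an aromatic carbon. For the measured compounds named here, no measured step introduces a dimethylamino substituent, so none bears on it directly; the steps that do concern this ring position were all flat, each within the scatter. The author therefore expects no step beyond the scatter in this assay for compound 4, the estimated step being no change at the digits printed from compound 3 to compound 4 (within the scatter). Compound 4 is estimated at 80%, with a range from 65% to 92%.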

Compound 4, largest response reached (reported as efficacy), in percent of the reference or control that the assay uses: 80%
Beside the measured number, compound 4's estimate shows no gap at the digits printed; the range from low to high includes it.
By their numbers in this assay, from the lowest: compounds 1, 2, 3 and 4 (each within the scatter of the next).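

Dimethylamino is a larger substituent than the fluorines, and it carries a nitrogen of its own, yet in this assay dimethylamino in place of hydrogen on the pyridin-4-yl group gives no change at the digits printed from compound 2 to compound 4 (within the scatter) as the cleanest single-point comparison. Against the fluorinated aryl groups the picture is the same, with 2-(dimethylamino)pyridin-4-yl in place of 2,6-difluoropyridin-4-yl giving no change at the digits printed from compound 3 to compound 4 (within the scatter) and in place of 3,5-difluorophenyl giving no change at the digits printed from compound 1 to compound 4 (within the scatter) on this aromatic carbon next to the ring nitrogen. Nothing available accounts for this flat maximal response.

As far as these compounds go, whether any group here can move the response beyond the scatter stays open, for instance a primary amine or a morpholine on the pyridin-4-yl group, or a piperidine in place of the whole aryl group. From the compounds shown here alone, the shared core's carboxymethyl group also remains open, as a longer chain such as carboxyethyl there would test a different place.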